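Ring-closing the amine of compound 1 into a methylpiperidine

The source may report more compounds than this note shows. Statements on the series, on what has been measured and on what is new or still open speak of the compounds shown alone.

The series shares one core, shown in compound 1 `CCN(Cc1c(C(F)(F)F)nc2n(-c3c(C)cc(C)cc3C)c(Cl)cn12)CC1CCC1`, and varies the amine attached to it. In an assay on cells for displacement of a labelled ligand from corticotropin-releasing factor receptor 1 (Homo sapiens), with a stated time of 100 min (on this read-out higher numbers stand for weaker inhibition and lower numbers for stronger inhibition), compound 1 gives 16 nM, the lowest of the three numbers. Compound 2 `Cc1cc(C)c(-n2c(Cl)cn3c(CN(CCC4CC4)CCC(F)(F)F)c(C(F)(F)F)nc23)c(C)c1` gives 110 nM in this assay, and compound 3 `CCN(Cc1ccc(Cl)c(Cl)c1)Cc1c(C(F)(F)F)nc2n(-c3c(C)cc(C)cc3C)c(Cl)cn12` gives 580 nM. Among the compounds with values here, the only single-point step measured is a 36-fold higher number from compound 1 to compound 3 (1.56 log units; beyond the scatter), showing that the amine substituents carry much of the binding. Compound 4 `Cc1cc(C)c(-n2c(Cl)cn3c(CN4CCC(C)CC4)c(C(F)(F)F)nc23)c(C)c1` is the next candidate; it differs from compound 1 by 4-methylpiperidin-1-yl in place of (cyclobutylmethyl)(ethyl)amino on a saturated chain carbon bound to an aromatic carbon. Within the data shown here, no measured pair closes an open dialkylamine into a ring, so the step has no direct precedent; the steps from compound 1 to compound 2 and to compound 3 both point to losses when the amine substituents depart from those of compound 1, and a modest loss is therefore expected here too. Compound 4 is estimated to give 50 nM in this assay, within 15 nM to 200 nM, meaning an expected 3.1-fold higher number from compound 1 to compound 4 (0.49 log units; beyond the scatter).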

Compound 4, inhibition constant: 3200 nM
For compound 4 the middle estimate is 64-fold (1.81 log units) below the measured one; the measured number lies above the stated range.
By their numbers in this assay, from the lowest: compound 1; then compound 2; then compound 3; then compound 4.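

In this assay, 4-methylpiperidin-1-yl in place of (cyclobutylmethyl)(ethyl)amino gives a 200-fold higher number from compound 1 to compound 4 (2.30 log units; beyond the scatter), a larger step than a 36-fold higher number from compound 1 to compound 3 (1.56 log units; beyond the scatter), and so the largest change from compound 1 among the compounds shown. The two groups differ by only one heavy atom, and both carry one hydrogen-bond acceptor, no hydrogen-bond donor and no net charge, so these counts alone do not follow the number at this place. Nothing measured here accounts for this loss.

On these data alone, it remains open whether the loss goes with closing the amine into a ring as such or with the methyl on that ring. A piperidin-1-yl without the methyl, a pyrrolidin-1-yl or a morpholin-4-yl on the same carbon would show whether other rings stand nearer compound 1 or compound 4.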